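A few compounds are considered here, and "the series" means these few. Any claim that something is new, unique, unknown or untested is made for them only; others in the source may bear on it.

Measured so far:
Compound 1 (`CCn1c([C@@H](C)NS(=O)(=O)c2ccc(Cl)cc2)nc2ccc(CN(C)C)cc21`): 30 mL.min-1.g-1
Compound 2 (`CCn1c([C@@H](C)NS(=O)(=O)c2ccccc2)nc2ccc(C(F)(F)F)cc21`): 14 mL.min-1.g-1

In an ADME assay (liver) for metabolic stability, with Liver microsome (Homo sapiens) as the target, read by LC-MS, using microsomes and NADPH, with a stated time of 5 min, at 37 degrees C (on this read-out lower numbers stand for slow clearance and higher numbers for fast clearance), compound 2 stands lowest of the two measured compounds at 14 mL.min-1.g-1 and compound 1 lies beyond the scatter above it. Compound 3 (`CCn1c([C@@H](C)NS(=O)(=O)c2ccc(CC(C)C)cc2)nc2ccc(C(F)(F)F)cc21`) has not yet been measured. The change from compound 2 to compound 3 is isobutyl in place of hydrogen on an aromatic carbon and puts isobutyl in place of hydrogen on an aromatic carbon. Within the data shown here, no measured pair isolates this change, so the expectation remains loose. A rise beyond the scatter is expected, with the estimated step of a 2.5-fold higher number from compound 2 to compound 3 (0.40 log units; beyond the scatter) as the working figure. For compound 3 the estimate is 35 mL.min-1.g-1 with an expected range from 16 mL.min-1.g-1 to 80 mL.min-1.g-1 in this read-out.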

Compound 3, intrinsic clearance in microsomes: > 100 mL.min-1.g-1
Compound 3 was reported as a limit; the forecaster's own chance of this, stated with the estimate: 3%; middle value at least 2.8-fold (0.45 log units) away from the limit.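

In this assay, among these compounds, phenyl to 4-isobutylphenyl gives an at least 7.1-fold higher number from compound 2 to compound 3 (0.85 log units; beyond the scatter), the first reading on this position, since compound 1 and compound 2 differ in more than one place. Compound 3 stands at a limit of the assay, so this step gives only a lower bound: the limit of > 100 mL.min-1.g-1 in this assay, at which 1 of the 3 values shown sits. The position is therefore not indifferent to what it carries on this core.

As far as these compounds go, how far compound 3 lies past the limit stays open. Also open, from the compounds shown here alone, is whether the rise needs isobutyl itself, or would also come with methyl, a hydroxyl-bearing chain or a carboxylic acid at this place.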